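Replacing Naphthalen-1-yl with 4-Fluorophenyl

This account rests on a few compounds, and the source may have more. Where it says the series, first, only, none or still open, it means among the compounds named here.

For the measured compounds named here, in an ADME assay on HEK-293T cells (Homo sapiens) for inhibition, read by CCK-8 assay, with a stated time of 48 h, tested at 20 uM (a lower number here means less inhibition of growth, a higher number more inhibition of growth at the concentration tested), compound 1 `Cc1ccc(S(=O)(=O)Oc2ccccc2/C=C(\C#N)C(=O)Nc2nnc(C)s2)cc1` gives 35%, while compound 2 `Cc1ccc(S(=O)(=O)Oc2ccccc2/C=C(\C#N)C(=O)Nc2nnc(Cc3cccc4ccccc34)s2)cc1` gives 23%, the lower of the two numbers so far. Compound 3 `Cc1ccc(S(=O)(=O)Oc2ccccc2/C=C(\C#N)C(=O)Nc2nnc(Cc3ccc(F)cc3)s2)cc1` has 4-fluorophenyl in place of naphthalen-1-yl on a saturated chain carbon bound to an aromatic carbon. Going by the values given here, one measured step bears on this change: a number 12 percentage points lower from compound 1 to compound 2 (beyond the scatter), which introduced the naphthalen-1-yl group. Among the compounds with values here, with only that modest step as a guide, a slight rise that stays within the scatter is expected, a number 5 percentage points higher from compound 2 to compound 3 (within the scatter). Compound 3 is estimated at 28%, with an expected range of 15% to 41%.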

Compound 3, percent growth inhibition at one concentration: 16%
Beside the measured number, compound 3's estimate is 12 percentage points above it; the range from low to high includes it.
By their numbers in this assay, from the lowest: compounds 3 and 2 (each within the scatter of the next); then compound 1.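

In this assay, the exchange of naphthalen-1-yl for 4-fluorophenyl gives a number 7 percentage points lower from compound 2 to compound 3 (within the scatter), so this position does not separate the two aromatic groups. A second aromatic group on the saturated chain carbon also gives a number 19 percentage points lower from compound 1 to compound 3 (beyond the scatter), which shows that the drop seen with compound 2 is not confined to naphthalen-1-yl. Nothing at hand explains these numbers. From the compounds shown here alone, it remains open whether an aromatic ring is needed on this carbon at all, or whether an amine or a carboxylic acid there would give a similar number.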